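A few compounds are considered here, and "the series" means these few. Any claim that something is new, unique, unknown or untested is made for them only; others in the source may bear on it.

Measured so far in a functional assay on HL-60 cells (Homo sapiens) for antiproliferative activity, read by MTT assay, with a stated time of 24 h; on this read-out higher numbers stand for weaker inhibition and lower numbers for stronger inhibition:
compound 1 `CCCCNC(=O)COc1ccc(C(=O)c2c(CCCC)oc3ccccc23)cc1`: > 50000 nM
compound 2 `CCCCc1oc2ccccc2c1C(=O)c1ccc(OCC(=O)Nc2cccc(OC)c2)cc1`: > 50000 nM

Compound 2 stands at > 50000 nM in this assay, and this is a limit, not a number. For the measured compounds named here, it has no company among measured numbers, as the series so far offers only (the limit of > 50000 nM in this assay, at which 2 of the 2 values shown sit).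

The next compound is compound 3 `CCCCc1oc2ccccc2c1C(=O)c1ccc(OCC(=O)NCc2ccccc2)cc1`. The change is benzyl in place of 3-methoxyphenyl on an amide-type nitrogen.

Going by the values given here, one measured step bears on this change, since it touches the same nitrogen: a step that the two limits leave unreadable from compound 1 to compound 2. Its size cannot be read, so it offers no magnitude to carry over. It shows only that neither butyl nor 3-methoxyphenyl at this place gave a number in this assay. On that basis, no step beyond the scatter is expected in this assay, and a further limit is the likeliest report. The expected step is a number no higher from compound 2 to compound 3 (the limit leaves the size open). The estimated value for compound 3 is 50000 nM, with an expected range of 20000 nM to 100000 nM.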

Compound 3, half-maximal inhibitory concentration: > 50000 nM
Compound 3 was reported as a limit; the forecaster's own chance of this, stated with the estimate: 80%; the middle value lies on the limit itself.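

No step can be read among compound 1, compound 2 and compound 3 in this assay, because each result is a limit and not a number: the limit of > 50000 nM in this assay, at which 3 of the 3 values shown sit.

The compounds shown leave open how butyl, 3-methoxyphenyl and benzyl on the amide-type nitrogen compare, and whether any group at this place gives a number in this assay.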